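Replacing One Ring on the Amide of Compound 2

The compounds below may be only part of what the source reports. "The series", "measured", "known", "first", "only" and "open" are said of these compounds alone.

In a functional assay on BaF3 cells (Mus musculus) for antiproliferative activity, read by CCK-8 assay and cell counting, with a stated time of 76 h (on this read-out higher numbers stand for weaker inhibition and lower numbers for stronger inhibition), compound 2 (`COc1cc2nccc(Oc3ccc(Nc4nn(C)cc4C(=O)Nc4ccccc4F)cc3)c2cc1C(N)=O`) gives 1710 nM and compound 1 (`COc1cc2nccc(Oc3ccc(Nc4nn(C)cc4C(=O)NC4CCCCCCC4)cc3)c2cc1C(N)=O`) gives 3210 nM and these two values sit within the scatter of each other. Compound 3 (`COc1cc2nccc(Oc3ccc(Nc4nn(C)cc4C(=O)NC4CCCC4)cc3)c2cc1C(N)=O`) has cyclopentyl in place of 2-fluorophenyl on an amide-type nitrogen, a change counted as cyclopentyl in place of 2-fluorophenyl on an amide-type nitrogen and not yet measured. Going by the values given here, only one measured step bears on it, namely a 1.9-fold lower number from compound 1 to compound 2 (0.27 log units; within the scatter) with 2-fluorophenyl in place of cyclooctyl on an amide-type nitrogen, and it lies within the scatter. No step beyond the scatter is expected, and the estimate is a 1.4-fold higher number from compound 2 to compound 3 (0.15 log units; within the scatter) for this change. In this assay compound 3 is expected at 2400 nM with an estimated range from 900 nM to 6000 nM overall.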

Compound 3, half-maximal inhibitory concentration: > 10000 nM
Compound 3 gave a limit, no number (the forecaster's own chance of this, stated with the estimate: 8%); at least 4.1-fold (0.61 log units) between middle value and limit.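

In this assay compound 3 gives only a limit of the assay, not a number: the limit of > 10000 nM in this assay, at which 1 of the 3 values shown sits. This shows that the ring on this amide-type nitrogen can matter, which the earlier pair, lying within the scatter, could not show: the change to cyclopentyl gives an at least 5.8-fold higher number from compound 2 to compound 3 (0.76 log units; beyond the scatter), and an at least 3.1-fold higher number from compound 1 to compound 3 (0.49 log units; beyond the scatter). Among the three rings shown, only cyclopentyl brings a step beyond the scatter.

As far as these compounds go, how weak compound 3 really is stays open. So does whether cyclohexyl, unsubstituted phenyl or a ring carrying an amine would behave like cyclopentyl or like the other two groups.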